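The compounds below may be only part of what the source reports. "The series", "measured", "known", "first", "only" and "open" are said of these compounds alone.

Measured compounds:
- compound 1, `O=S(=O)(c1cc(Cl)cc(Cl)c1)c1cnc2cc(F)ccc2c1-c1ccc(F)cc1`: 0.18 mL/min
- compound 2, `COc1ccc(-c2c(S(=O)(=O)c3ccc(F)c(F)c3)cnc3cc(F)ccc23)cc1`: 1.1 mL/min

In an ADME assay on microsomes from liver (Homo sapiens) for metabolic stability, tested at 2.5 uM (a lower number here means slower removal, a higher number faster removal of the compound), compound 2 gives the higher of the two numbers, and compound 1 gives the lower one; the gap between compound 1 and compound 2 is beyond the scatter. Going by the values given here, compound 1 and compound 2 differ at more than one place, so no single step between measured compounds is available and the gap cannot be assigned to any one change.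

Compound 3, `COc1ccc(-c2c(S(=O)(=O)c3cc(Cl)cc(Cl)c3)cnc3cc(F)ccc23)cc1`, is not yet measured in this assay. Its difference from compound 2: 3,5-dichlorophenyl in place of 3,4-difluorophenyl on a sulfonyl sulfur. The group that enters is the same one carried by compound 1, which in this assay gives 0.18 mL/min. On that basis a downward step is expected, of moderate size, with the measured scatter allowed for.

For compound 3 in this assay the expected value is 0.5 mL/min, within 0.2 mL/min to 1.3 mL/min. The step expected is a 2.2-fold lower number from compound 2 to compound 3 (0.34 log units; beyond the scatter).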

Compound 3, intrinsic clearance in a liver preparation (reported as CLH), per the amount of preparation that the assay uses: 1 mL/min
For compound 3 the middle estimate is 2.0-fold (0.30 log units) below the measured one; low and high end bracket the measured number.
By their numbers in this assay, from the lowest: compound 1; then compounds 3 and 2 (each within the scatter of the next).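

Putting 3,5-dichlorophenyl in place of 3,4-difluorophenyl on a sulfonyl sulfur gives, in this assay, a 1.1-fold lower number from compound 2 to compound 3 (0.04 log units; within the scatter) with methoxy held fixed, so this exchange shows no resolvable effect in that setting. Methoxy in place of fluoro on an aromatic carbon gives a 5.6-fold higher number from compound 1 to compound 3 (0.74 log units; beyond the scatter) with 3,5-dichlorophenyl held fixed, so the low number of compound 1 does not travel with the 3,5-dichlorophenyl group alone. Nothing at hand accounts for either step.

Going by these compounds, whether the exchange on the sulfonyl sulfur stays as flat with fluoro in place of methoxy remains open. Also open, on these data alone, is how a hydroxy group, an amine or a longer alkoxy chain on that aromatic carbon would compare with methoxy and fluoro in this assay for this series.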